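Side-chain swap on the shared core

The source may hold more compounds than are shown below. What is called first, only, known or untested is meant among the compounds shown, and "the series" means these compounds.

Among the compounds with values here, compound 2 `CC[C@H](C)[C@H](NC(=O)CN(c1ncnc2c1ncn2C1CCCCO1)C1CC1)C(=O)OCc1ccccc1` gives 20.4% in a functional assay on the whole organism (Tail, strain ICR) with Mus musculus as the target, in the tail flick test, with a stated time of 120 min, at a dose of 25 umol/kg by the oral route (a lower number here means a weaker effect, a higher number a stronger effect of the compound at the dose given), and stands highest of the two numbers so far, yet compound 1 `O=C(CN(c1nc(Cl)nc2[nH]cnc12)C1CC1)N[C@@H](CC(=O)OCc1ccccc1)C(=O)OCc1ccccc1`, which gives 12.1% in this assay, lies within the scatter of it, so no order between the two is claimed. Compound 3 `O=C(CN(c1ncnc2c1ncn2C1CCCCO1)C1CC1)N[C@@H](CC(=O)OCc1ccccc1)C(=O)OCc1ccccc1` is not yet measured in this assay. It differs from compound 2 in one place: (benzyloxycarbonyl)methyl in place of sec-butyl on a saturated chain carbon bound to an amide-type nitrogen and a carbonyl carbon. Within the data shown here, no step between measured compounds is available to guide the size of this change. The expected step in this assay is small, if anything downward, and within the scatter: a number 6.4 percentage points lower from compound 2 to compound 3 (within the scatter). Compound 3 is therefore estimated at 14%, with a range from 3% to 28%.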

Compound 3, a percentage reported as activity, at one dose (the size of the read-out at that dose, not a potency): 7.82%
Beside the measured number, compound 3's estimate is 6.2 percentage points above it; the range from low to high includes it.
By their numbers in this assay, from the lowest: compounds 3, 1 and 2 (each within the scatter of the next, the first and the last beyond it).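

In this assay the change at the saturated chain carbon bound to an amide-type nitrogen and a carbonyl carbon now has a size: a number 12.6 percentage points lower from compound 2 to compound 3 (beyond the scatter) when (benzyloxycarbonyl)methyl replaces sec-butyl. Within the data shown here, this is the only single-place step, so the position is not indifferent to its side chain, although one pair gives a direction for this swap alone. Nothing at hand bears on why the number falls.

Going by these compounds, whether a methyl group or a free carboxylic acid at this position would give a higher or lower number remains open. Also open, on these data alone, is whether the same step holds on the core of compound 1.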